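The source may report more compounds than this note shows. Statements on the series, on what has been measured and on what is new or still open speak of the compounds shown alone.

Compound 1 `O=C(O)Cc1sc(C(c2ccc(F)cc2)c2ccc(F)cc2)nc1-c1cccc(F)c1` gives 18 nM in an in vitro functional assay on HEK285-7 cells for antagonist activity at prostaglandin D2 receptor 2 (Homo sapiens), read by BRET and beta-arrestin recruitment; a lower number here means a stronger inhibitor, a higher number a weaker inhibitor.
Compound 2 `O=C(O)Cc1sc(C(c2ccc(F)cc2)c2ccc(F)cc2)nc1-c1ccncc1` gives 40 nM.
Compound 3 `O=C(O)Cc1sc(C(c2ccc(F)cc2)c2ccc(F)cc2)nc1-c1ccnc(F)c1` gives 4.7 nM.

Compound 3 stands lowest of the three, with a 3.8-fold lower number from compound 1 to compound 3 (0.58 log units; beyond the scatter) and an 8.5-fold lower number from compound 2 to compound 3 (0.93 log units; beyond the scatter). Compound 4 `O=C(O)Cc1sc(C(c2ccc(F)cc2)c2ccc(F)cc2)nc1-c1ccnc(N2CCC2)c1` differs from compound 3 by azetidin-1-yl in place of fluoro on an aromatic carbon. Among the measured compounds shown here, only one measured step touches this position: the fluoro entering there gave an 8.5-fold lower number from compound 2 to compound 3 (0.93 log units; beyond the scatter), while a 2.2-fold higher number from compound 1 to compound 2 (0.35 log units; beyond the scatter) concerns a different position. For the measured compounds named here, no measured pair shows a group of the size of azetidin-1-yl at that carbon, so the direction of the step in this assay is open. Compound 4 is expected to lie close to compound 3, with a modest shift as a 2.1-fold higher number from compound 3 to compound 4 (0.33 log units; beyond the scatter). The estimate for compound 4 is 10 nM, between 3 nM and 40 nM.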

Compound 4, half-maximal inhibitory concentration: > 100000 nM
Compound 4 was reported as a limit (the forecaster's own chance of this, stated with the estimate: 2%); middle value at least 10000-fold (4.00 log units) from the limit.
By their numbers in this assay, from the lowest: compound 3; then compound 1; then compound 2. At a limit, above all of these: compound 4.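

In this assay compound 4 is reported only as a limit, > 100000 nM. At this carbon next to the ring nitrogen, fluoro had given an 8.5-fold lower number from compound 2 to compound 3 (0.93 log units; beyond the scatter), whereas azetidin-1-yl gives an at least 2500-fold higher number from compound 2 to compound 4 (3.39 log units; beyond the scatter) and an at least 21000-fold higher number from compound 3 to compound 4 (4.32 log units; beyond the scatter), so the step in fact runs the opposite way and is large. Against the 3-fluorophenyl group, the 2-(azetidin-1-yl)pyridin-4-yl group gives an at least 5500-fold higher number from compound 1 to compound 4 (3.74 log units; beyond the scatter), the same large direction.

As far as these compounds go, whether this loss belongs to the four-membered ring or to any amine at this carbon stays open. From the compounds shown here alone, how a methyl, a methoxy or a dimethylamino group would behave there is also open.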